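The source may report more compounds than this note shows. Statements on the series, on what has been measured and on what is new or still open speak of the compounds shown alone.

Measured so far in a functional assay on HL-60 cells (Homo sapiens) for inhibition; a higher number here means a weaker inhibitor, a lower number a stronger inhibitor:
- Compound 1 `CC(C)CN(C)Cc1ccc(C2CCCN(C)C2)cc1`: "not determined" (no result reported)
- Compound 2 `CC(C)CCCN(C)Cc1ccc(C2CCCN(C)C2)cc1`: "not determined" (no result reported)
- Compound 3 `CN(Cc1ccc(Cl)cc1)Cc1ccc(C2CCCN(C)C2)cc1`: 1290 nM

Among the compounds with values here, compound 3 holds the only number in this small set, so it cannot yet be ranked as strong or weak against its relatives. Neither compound 1 nor compound 2 offers a result for comparison.

The next compound to be tested is compound 4 `CN(C/C=C/c1ccccc1)Cc1ccc(C2CCCN(C)C2)cc1`, which keeps the shared core and changes one group: 2-phenylethenyl in place of 4-chlorophenyl on a saturated chain carbon bound to an amine nitrogen. Within the data shown here, with no measured pair to show how this assay responds to a change at this place, there is no firm basis for predicting a direction. Compound 3 at 1290 nM is the only anchor, so the expectation is no step beyond the usual scatter, with wide uncertainty on both sides. The estimated change is a 1.3-fold lower number from compound 3 to compound 4 (0.11 log units; within the scatter). For compound 4 the expected value is 1000 nM, with an estimated range from 250 nM to 4000 nM.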

Compound 4, half-maximal inhibitory concentration: 1100 nM
Estimate against measurement, compound 4: 1.1-fold (0.04 log units) below, within the range that was stated.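

In this assay, within the data shown here, replacing 4-chlorophenyl with 2-phenylethenyl on a saturated chain carbon bound to an amine nitrogen gives a 1.2-fold lower number from compound 3 to compound 4 (0.07 log units; within the scatter), the first measured pair at this position. So this place accepts two different aromatic groups, one carrying chlorine and the other a double bond outside the ring, without a change that the assay can separate from scatter. Nothing available explains why the two compounds read alike.

On these data alone, compound 1 and compound 2 have no result, so it remains unknown whether an aromatic ring at this place matters at all. As far as these compounds go, how a carboxylic acid, an amide or a pyridine ring would read at the same place in this assay also remains open.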